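Three Sulfonamides at the Limit and a Nitrophenyl Successor

The compounds below may be only part of what the source reports. "The series", "measured", "known", "first", "only" and "open" are said of these compounds alone.

Three compounds were measured in a functional assay on KYSE-510 cells (Homo sapiens) for antiproliferative activity, read by crystal violet staining, with a stated time of 96 h; on this read-out higher numbers stand for weaker inhibition of growth and lower numbers for stronger inhibition of growth:
Compound 1 `Cc1ccc(S(=O)(=O)NC2=NCCN2C(=S)SN2CCn3c2nsc3=S)cc1` gives >= 20000 nM, a limit of the assay.
Compound 2 `O=S(=O)(NC1=NCCN1C(=S)SN1CCn2c1nsc2=S)c1ccc(C(F)(F)F)cc1` gives >= 20000 nM, a limit of the assay.
Compound 3 `COc1ccc(S(=O)(=O)NC2=NCCN2C(=S)SN2CCn3c2nsc3=S)cc1OC` gives >= 20000 nM, again only a limit.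

Compound 3 therefore stands at the same limit as the other two. The steps a step that the two limits leave unreadable from compound 1 to compound 2, a step that the two limits leave unreadable from compound 1 to compound 3 and a step that the two limits leave unreadable from compound 2 to compound 3 all lack a readable size because the limit of >= 20000 nM in this assay, at which 3 of the 3 values shown sit, caps every value.

Compound 4 `O=[N+]([O-])c1ccc(S(=O)(=O)NC2=NCCN2C(=S)SN2CCn3c2nsc3=S)cc1` differs from compound 3 by 4-nitrophenyl in place of 3,4-dimethoxyphenyl on a sulfonyl sulfur. The three measured steps each exchange the group on the sulfonyl sulfur, as this change does, and none of them left the limit. Compound 4 is therefore expected to give 20000 nM in this assay, within 8000 nM to 50000 nM, most likely as a limit once more. The expected step of a number no higher from compound 3 to compound 4 (the limit leaves the size open) is an estimate of no readable change.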

Compound 4, concentration for 50% growth inhibition: >= 20000 nM
Compound 4 was reported as a limit (the forecaster's own chance of this, stated with the estimate: 80%); the middle value lies on the limit itself.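

No step between compound 4 and compound 1, compound 2 or compound 3 can be read, because each value is only a limit: the limit of >= 20000 nM in this assay, at which 4 of the 4 values shown sit.

The compounds shown leave open whether any group on the sulfonyl sulfur gives a readable value.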